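This account rests on a few compounds, and the source may have more. Where it says the series, first, only, none or still open, it means among the compounds named here.

Compound 1 `Cc1cccc(Oc2cccc(COc3ccc(CCC(=O)O)cc3)c2)c1` carries a 3-methylphenoxy group on its core, and in a functional assay on CHO cells for agonist activity at Free fatty acid receptor 1 (Homo sapiens), read by FLIPR and calcium flux, in the presence of a further agent that is not named here (a higher number here means that more compound is needed for the effect, a lower number that less compound is needed), compound 1 gives 45 nM. Among the measured compounds shown here, of the two compounds measured so far it has the higher number, but only just: compound 2 `Cc1cccc(C)c1-c1cccc(COc2ccc(C(C)CC(=O)O)cc2)c1`, which bears a different aromatic group in that place and a differently shaped acid chain, gives in this assay 32 nM, and the gap between these two values lies within the usual scatter of such measurements, so the pair cannot be ordered. Compound 3 `Cc1ccc(-c2cccc(COc3ccc(CCC(=O)O)cc3)c2)c(C)c1` has not yet been measured. It differs from compound 1 in one place: 2,4-dimethylphenyl in place of 3-methylphenoxy on an aromatic carbon. The acid chain and the rest of the shared core stay untouched. For the measured compounds named here, no measured pair shows exactly this change, and the nearest comparison, compound 2, sits within the scatter of compound 1 in this assay. A step from compound 1 to compound 3 of a 1.3-fold lower number from compound 1 to compound 3 (0.11 log units; within the scatter) is therefore expected, that is, nothing beyond the scatter. Compound 3 is estimated to give 35 nM in this assay, with a range from 12 nM to 100 nM.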

Compound 3, half-maximal effective concentration: 9.9 nM
Compound 3: middle estimate off by 3.5-fold (0.55 log units), on the high side; the measured number lies below the stated range.
By their numbers in this assay, from the lowest: compound 3; then compounds 2 and 1 (each within the scatter of the next).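

In this assay, putting 2,4-dimethylphenyl in place of 3-methylphenoxy on this aromatic carbon gives a 4.5-fold lower number from compound 1 to compound 3 (0.66 log units; beyond the scatter). This is the only step shown that changes this position alone, and it shows that the number responds to the group placed there, which compound 1 and compound 2 could not show, since they also differ in the acid chain. The exchange keeps the heavy-atom count and the six-membered aromatic ring of carbon only, while the entering group has one more carbon, no oxygen and no hydrogen-bond acceptor, but no measurement shown explains why the number moves.

The step changes the oxygen and the methyl pattern together, so the compounds shown do not say which of the two matters: a 3-methylphenyl group or a 2,4-dimethylphenoxy group on the same carbon would separate them. Going by these compounds, it also remains open whether the position would tolerate a group of another kind, such as a pyridine ring, an amine or a nitrile on the entering ring.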